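The compounds below may be only part of what the source reports. "The series", "measured", "known", "first", "only" and "open" are said of these compounds alone.

Measured so far in a functional assay on KBVIN cells (Homo sapiens) for antiproliferative activity, read by sulforhodamine B assay, with a stated time of 3 days; a higher number here means that more compound is needed for the effect, a lower number that less compound is needed
- compound 1 `CCC1=C(O)c2c(oc(-c3ccc(C)cc3C)cc2=O)C(CC)(CC)C1=O` gives 8.52 uM
- compound 2 `CCC1=C(O)c2c(oc(-c3cc(C)ccc3C)cc2=O)C(CC)(CC)C1=O` gives 3.41 uM

For the measured compounds named here, compound 2 holds the lower of the two numbers, and its only neighbour is compound 1. Compound 3 `CCC1=C(O)c2c(oc(-c3cc(C)ccc3F)cc2=O)C(CC)(CC)C1=O` follows from compound 2 by one exchange, fluoro in place of methyl on an aromatic carbon, ortho to a large group and para to a methyl group, which turns 2,5-dimethylphenyl into 2-fluoro-5-methylphenyl (fluoro in place of methyl on an aromatic carbon). Going by the values given here, the only measured step, a 2.5-fold lower number from compound 1 to compound 2 (0.40 log units; beyond the scatter), changes the same aryl ring but exchanges no methyl for fluoro, so it gives only a rough size for changes on this ring. Among the compounds with values here, no measured step gives the direction. A modest shift toward a higher number is expected, with little confidence in that direction, and the estimated step is a 1.5-fold higher number from compound 2 to compound 3 (0.17 log units; within the scatter). For compound 3 the expected value is 5 uM, with an estimated range of 2 uM to 13 uM.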

Compound 3, concentration for half-maximal effect: 3.24 uM
The estimate for compound 3 lay 1.5-fold (0.19 log units) above the measured number; the range from low to high includes it.
By their numbers in this assay, from the lowest: compounds 3 and 2 (each within the scatter of the next); then compound 1.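

In this assay, fluoro in place of methyl on the aromatic carbon ortho to a large group gives a 1.1-fold lower number from compound 2 to compound 3 (0.02 log units; within the scatter), so this exchange leaves the number within the scatter, and a methyl at this place is not required to hold it among these compounds. The 2-fluoro-5-methylphenyl group in place of 2,4-dimethylphenyl gives a 2.6-fold lower number from compound 1 to compound 3 (0.42 log units; beyond the scatter), which is beyond the scatter and modest in size, so the separation from compound 1 persists with either group at this place. Nothing available accounts for this tolerance of the exchange.

Open, going by these compounds, is whether a larger or different group at this place, such as methoxy or an amine, would hold the number as well. Also open, on these data alone, is what the methyl group para to this place contributes, since compound 2 and compound 3 both carry it.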